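The source may hold more compounds than are shown below. What is called first, only, known or untested is meant among the compounds shown, and "the series" means these compounds.

Measured compounds:
compound 1, `CC1(C)[C@H]2CC[C@]1(C)N(Cc1cn(-c3ccccc3O)nn1)C(=O)C2`, 540 nM;
compound 2, `CC1(C)[C@H]2CC[C@]1(C)N(Cc1cn(-c3ccc(F)cc3)nn1)C(=O)C2`, 40 nM;
compound 3, `CC1(C)[C@H]2CC[C@]1(C)N(Cc1cn(-c3cccc(C#N)c3)nn1)C(=O)C2`, 320 nM.

In a functional assay on LoVo cells (Homo sapiens) for inhibition, read by MTT assay, with a stated time of 24 h (on this read-out higher numbers stand for weaker inhibition and lower numbers for stronger inhibition), compound 3 gives 320 nM, the second highest of the three numbers; its nearest neighbour is compound 1, with a 1.7-fold lower number from compound 1 to compound 3 (0.23 log units; within the scatter), while compound 2 lies furthest away, with an 8.0-fold higher number from compound 2 to compound 3 (0.90 log units; beyond the scatter).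

Compound 4, `Cc1cccc(-n2cc(CN3C(=O)C[C@@H]4CC[C@@]3(C)C4(C)C)nn2)c1`, differs from compound 3 in one place: methyl in place of cyano on an aromatic carbon.

Going by the values given here, no measured step exchanges cyano for methyl. Among the compounds with values here, the steps that bear on it only show how much the substituent on the phenyl ring can move this read-out: a 14-fold lower number from compound 1 to compound 2 (1.13 log units; beyond the scatter) and an 8.0-fold higher number from compound 2 to compound 3 (0.90 log units; beyond the scatter) are beyond the scatter, whereas a 1.7-fold lower number from compound 1 to compound 3 (0.23 log units; within the scatter) is within it. Within the data shown here, with no closer precedent, a step in either direction of modest size is possible, and compound 4 is expected to stay close to compound 3, at a 1.3-fold lower number from compound 3 to compound 4 (0.11 log units; within the scatter). The estimate for compound 4 is therefore 250 nM, with a range from 80 nM to 800 nM.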

Compound 4, half-maximal inhibitory concentration: 50 nM
For compound 4 the middle estimate is 5.0-fold (0.70 log units) above the measured one, and the stated range ends above it.
By their numbers in this assay, from the lowest: compounds 2 and 4 (each within the scatter of the next); then compounds 3 and 1 (each within the scatter of the next).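

In this assay, exchanging cyano for methyl on this aromatic carbon is a step beyond the scatter (a 6.4-fold lower number from compound 3 to compound 4 (0.81 log units; beyond the scatter)), so the earlier 3-cyanophenyl result does not speak for every group at this place. The 3-methylphenyl group stands level with the 4-fluorophenyl group (a 1.3-fold higher number from compound 2 to compound 4 (0.10 log units; within the scatter)), a gap within the scatter, and clear of the 2-hydroxyphenyl group (an 11-fold lower number from compound 1 to compound 4 (1.03 log units; beyond the scatter)), so two different phenyl substituents now share the low end of these numbers. Nothing on hand explains why methyl and cyano part here.

From the compounds shown here alone, whether a longer chain such as ethyl, or an amine or a carboxylic acid, would hold these low numbers at the same place remains open. Also open, going by these compounds, is whether methyl would behave the same way on the other carbons of the phenyl ring.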